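The source may hold more compounds than are shown below. What is called first, only, known or untested is meant among the compounds shown, and "the series" means these compounds.

Of the compounds shown here, three have been tested in an assay on CHO cells for displacement of a labelled ligand from adenosine receptor A3 (Homo sapiens), read by scintillation counting, tested at 10 uM; a higher number here means more inhibition at the concentration tested (going by the name of the read-out), a lower number less inhibition. Compound 1 `CC(C)(C)Cc1csc(N)c1C(=O)c1ccc(Cl)cc1` gives 5%. Compound 2 `CC(C)(C)Cc1c(-c2ccc(Cl)cc2)sc(N)c1C(=O)c1ccc(Cl)cc1` gives 1%, and compound 3 `Cc1ccc(-c2sc(N)c(C(=O)c3ccc(Cl)cc3)c2CC(C)(C)C)cc1` gives 1%. The step of no change at the digits printed from compound 2 to compound 3 (within the scatter) belongs to the change (methyl in place of chloro on an aromatic carbon). The cores of compound 1 and compound 2 differ by hydrogen in place of 4-chlorophenyl on an aromatic carbon, and the step of a number 4 percentage points lower from compound 1 to compound 2 (within the scatter) shows that this difference leaves the read-out within the scatter.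

Compound 4 `Cc1ccc(C(=O)c2c(CC(C)(C)C)csc2N)cc1` has not yet been measured. It differs from compound 1 by methyl in place of chloro on an aromatic carbon, the same change as from compound 2 to compound 3. Because the measured step of no change at the digits printed from compound 2 to compound 3 (within the scatter) stayed within the scatter and all three known numbers are low, the expected step is a number 1 percentage points lower from compound 1 to compound 4 (within the scatter). Compound 4 is therefore estimated at 4%, most likely between 0% and 12%.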

Compound 4, a percentage reported as inhibition, at one concentration (the size of the read-out at that concentration, not a potency): 1%
Compound 4: middle estimate off by 3 percentage points, on the high side; low and high end bracket the measured number.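

In this assay, putting methyl in place of chloro on the shared core gives this step: a number 4 percentage points lower from compound 1 to compound 4 (within the scatter). Set beside the same change on the core of compound 2, the two steps agree: the same change on two cores in this assay, no change at the digits printed (within the scatter) from compound 2 to compound 3 and a number 4 percentage points lower (within the scatter) from compound 1 to compound 4, 4 percentage points apart, within the scatter of two such steps This does not show that the change is neutral in general: all four compounds give small numbers at a single concentration, and a read-out this low could hide a real difference between chloro and methyl.

Still open, on these data alone, is whether a methoxy group, an amine or a carboxylic acid in place of the chloro would raise the inhibition. Also open, as far as these compounds go, is whether the same swap stays silent on a compound with a clearly higher number.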